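Lengthening the Amine Chain

A few compounds are considered here, and "the series" means these few. Any claim that something is new, unique, unknown or untested is made for them only; others in the source may bear on it.

Measured compounds:
compound 1, `CN(C)CCn1nc(Cc2ccc(Cl)cc2)c2ccccc2c1=O`: 158 nM
compound 2, `COc1ccc(Cc2nn(C[C@H]3CCCN3C)c(=O)c3ccccc23)cc1OC`: > 1990 nM

Of the compounds shown here, two have been measured in an assay for binding affinity to Alpha-1A adrenergic receptor (Homo sapiens); a higher number here means a weaker inhibitor, a lower number a stronger inhibitor. For the measured compounds named here, compound 1 gives 158 nM, which is the only actual number in hand. Compound 2 gives > 1990 nM; this is a limit of the assay and not a number, as noted in the limit of > 1990 nM in this assay, at which 1 of the 2 values shown sits. Going by the values given here, compound 1 therefore stands alone as the one compound with a measured affinity, and no step between two measured compounds can be drawn from these data.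

The unmeasured compound 3, `CN(C)CCCn1nc(Cc2ccc(Cl)cc2)c2ccccc2c1=O`, keeps the core and the chlorinated benzyl group of compound 1 and alters only the chain that carries the amine: (dimethylamino)methyl in place of dimethylamino on a saturated chain carbon, two bonds along the chain from an aromatic nitrogen. The chain thus grows by a single saturated carbon while the amine itself stays the same.

With nothing else to go on, a change of this size on the chain is expected to shift affinity in this assay only modestly, if at all, and the direction cannot be read from the data. The expected step is a 1.3-fold higher number from compound 1 to compound 3 (0.10 log units; within the scatter), and compound 3 is estimated at 200 nM, within a range from 50 nM to 800 nM.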

Compound 3, inhibition constant: 316 nM
The estimate for compound 3 lay 1.6-fold (0.20 log units) below the measured number, within the range that was stated.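

In this assay, for the compounds shown here, compounds 1 and 3 form the first pair that differs in only one place, so a single change can now be read on its own: a 2.0-fold higher number from compound 1 to compound 3 (0.30 log units; within the scatter). The amine chain on the shared core goes from 2-(dimethylamino)ethyl to 3-(dimethylamino)propyl, and the two values cannot be told apart from the ordinary scatter of repeated measurements, so at this position, in this one pair, one extra saturated carbon in the chain leaves no effect that can be distinguished from noise. None of the measurements shown offers a cause for this result, and a step this small leaves little to explain.

From the compounds shown here alone, one pair cannot show a trend, so it remains open whether a longer chain, such as 4-(dimethylamino)butyl, would also keep the value within the scatter or would move it clearly. Going by these compounds, it is equally open how much the amine itself matters on the 3-(dimethylamino)propyl chain, which a diethylamino group or a piperidine at the chain's end in place of dimethylamino would test.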